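Side-chain variation on the amino acid carbon: compound 4

The compounds below may be only part of what the source reports. "The series", "measured", "known", "first", "only" and "open" are said of these compounds alone.

The series shares one core and varies the group on a saturated chain carbon bound to an amide-type nitrogen and a carbonyl carbon. In a functional assay on the whole organism (Tail, strain ICR) with Mus musculus as the target, in the tail flick test, with a stated time of 90 min, at a dose of 25 umol/kg by the oral route (a higher number here means a stronger effect of the compound at the dose given, a lower number a weaker effect), compound 1 `C[C@H](NC(=O)CN(c1nc(Cl)nc2[nH]cnc12)C1CC1)C(=O)OCc1ccccc1` gives 44.2%, compound 2 `CC(C)[C@H](NC(=O)CN(c1nc(Cl)nc2[nH]cnc12)C1CC1)C(=O)OCc1ccccc1` gives 51.3%, and compound 3 `C[C@@H](O)[C@H](NC(=O)CN(c1nc(Cl)nc2[nH]cnc12)C1CC1)C(=O)OCc1ccccc1` gives 29.9%. Compound 3 stands lowest of the three numbers: the step of a number 14.3 percentage points lower from compound 1 to compound 3 (beyond the scatter) and the step of a number 21.4 percentage points lower from compound 2 to compound 3 (beyond the scatter) both lie beyond the scatter, while a number 7.1 percentage points higher from compound 1 to compound 2 (within the scatter) does not.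

Compound 4 `N=C(N)NCCC[C@H](NC(=O)CN(c1nc(Cl)nc2[nH]cnc12)C1CC1)C(=O)OCc1ccccc1` differs from compound 3 by a group of 7 heavy atoms (4 carbon, 3 nitrogen; no ring) in place of a group of 3 heavy atoms (2 carbon, 1 oxygen; no ring), on a saturated chain carbon bound to an amide-type nitrogen and a carbonyl carbon. For the measured compounds named here, the steps that bear on this change are 1>3 and 2>3, both modest lowerings when 1-hydroxyethyl replaced a group without donors. Going by the values given here, no measured step covers the entering group itself, and compound 3 is already the lowest number, so no step beyond the scatter is expected in this assay. The step of a number 0.1 percentage points higher from compound 3 to compound 4 (within the scatter) is expected to stay within the scatter. For compound 4 the estimate is 30%, with a range from 10% to 55%.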

Compound 4, a percentage reported as activity, at one dose (the size of the read-out at that dose, not a potency): 30.4%
Compound 4: middle estimate off by 0.4 percentage points, on the low side, within the range that was stated.
By their numbers in this assay, from the lowest: compounds 3 and 4 (each within the scatter of the next); then compounds 1 and 2 (each within the scatter of the next).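

In this assay, the position on a saturated chain carbon bound to an amide-type nitrogen and a carbonyl carbon accepts a group of 7 heavy atoms with 3 hydrogen-bond donors without separating it from 1-hydroxyethyl: a number 0.5 percentage points higher from compound 3 to compound 4 (within the scatter). The lower level seen with 1-hydroxyethyl therefore recurs with a quite different group, as shown by a number 13.8 percentage points lower from compound 1 to compound 4 (beyond the scatter) and by a number 20.9 percentage points lower from compound 2 to compound 4 (beyond the scatter). Among these four compounds, the two groups carrying hydrogen-bond donors, in compound 3 and compound 4, both lie beyond the scatter below the methyl of compound 1 and the isopropyl of compound 2, and no compound goes against this.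

Nothing available gives a reason for these levels. As far as these compounds go, whether an amine or a carboxylic acid at this position would read with compound 3 and compound 4 or with compound 1 and compound 2 remains open.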